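This account rests on a few compounds, and the source may have more. Where it says the series, first, only, none or still open, it means among the compounds named here.

Of the compounds shown here, three built on the core of compound 1 have been tested so far, and they differ only in one aromatic group. In a functional assay on HT-1080 cells (Homo sapiens) for cytotoxicity, read by MTT assay, with a stated time of 72 h (on this read-out higher numbers stand for weaker inhibition and lower numbers for stronger inhibition), compound 1 (`COc1cccc(/C=C2\CCC/C(=C\c3cccc(Cl)c3)C2=O)c1OC`) gives 10300 nM. Compound 2 (`COc1cccc(/C=C2\CCC/C(=C\c3ccccc3Br)C2=O)c1OC`) gives 10800 nM, and the measured step is a 1.0-fold higher number from compound 1 to compound 2 (0.02 log units; within the scatter).

Compound 3 (`COc1cccc(/C=C2\CCC/C(=C\c3ccc(O)cc3)C2=O)c1OC`) gives > 20000 nM, which is a limit of the assay and not a number. The steps that reach it are an at least 1.9-fold higher number from compound 1 to compound 3 (0.28 log units; that floor lies within the scatter) and an at least 1.8-fold higher number from compound 2 to compound 3 (0.26 log units; that floor lies within the scatter). On these data alone, both are only floors, so their true size remains open.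

Compound 4 (`COc1cccc(/C=C2\CCC/C(=C\c3ccc(O)c(Cl)c3)C2=O)c1OC`) differs from compound 3 by one change, chloro in place of hydrogen on an aromatic carbon, ortho to a hydroxy group. Among the compounds with values here, no measured step makes this exact change. The nearest guides are the two steps to compound 3, which compare its 4-hydroxyphenyl with the 3-chlorophenyl of compound 1 at 10300 nM and the 2-bromophenyl of compound 2 at 10800 nM. They suggest, weakly, that adding the chloro could bring the number down toward those values, while the hydroxy group stays in place. The expected change is an at least 1.6-fold lower number from compound 3 to compound 4 (0.22 log units; that floor lies within the scatter), a modest move in that direction. For compound 4 the estimate is 12000 nM, with an expected range of 5000 nM to 20000 nM.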

Compound 4, half-maximal inhibitory concentration: 14300 nM
The estimate for compound 4 lay 1.2-fold (0.08 log units) below the measured number; low and high end bracket the measured number.
By their numbers in this assay, from the lowest: compounds 1, 2 and 4 (each within the scatter of the next). At a limit, above all of these: compound 3.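

In this assay, chloro on the aromatic carbon ortho to a hydroxy group turns a result without a number into a measured one, with an at least 1.3-fold lower number from compound 3 to compound 4 (0.14 log units; that floor lies within the scatter). On these data alone, compound 3 stands at a limit, so the true size of that step stays open: the limit of > 20000 nM in this assay, at which 1 of the 4 values shown sits. The hydroxy group alone does not put a compound at the limit, as compound 4 carries one and goes against that reading: the change that adds it gives a 1.4-fold higher number from compound 1 to compound 4 (0.14 log units; within the scatter), and the comparison with the 2-bromophenyl group gives a 1.3-fold higher number from compound 2 to compound 4 (0.12 log units; within the scatter).

As far as these compounds go, it remains open whether an amino group or a fluoro in place of this chloro, ortho to the same hydroxy group, would also give a measured number. From the compounds shown here alone, compounds 1, 2 and 4 all lie within the scatter of one another, so it is also open whether any change on this aromatic ring can move the number clearly beyond that scatter in the direction of stronger inhibition.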